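This account rests on a few compounds, and the source may have more. Where it says the series, first, only, none or still open, it means among the compounds named here.

Measured compounds:
compound 1, `CC#C[C@H]1CN(S(=O)(=O)c2ccc(N)nc2)CCN1c1ccc(C(C)(O)C(F)(F)F)nc1`: 1450 nM
compound 2, `CC#C[C@H]1CN(S(=O)(=O)c2ccc(N)nc2)CCN1c1ccc(S(=O)(=O)Nc2ccccc2)cc1`: > 12500 nM

In an assay on cells (Hepatocyte) for inhibition of glucokinase regulatory protein (Mus musculus), with stated times of 20 min and 40 min (on this read-out higher numbers stand for an effect only at larger amounts of compound and lower numbers for an effect already at smaller amounts), compound 1 gives 1450 nM. Compound 2 reaches only a limit of this assay, > 12500 nM. Of the two values shown, compound 2 is the one that sits at the limit of > 12500 nM in this assay, at which 1 of the 2 values shown sits, so its true position on the scale is not known. Among the measured compounds shown here, no pair of measured compounds differs in a single place, so no measured step exists to lean on.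

Compound 3, `CC#C[C@H]1CN(S(=O)(=O)c2ccc(N)nc2)CCN1c1ccc(C(C)=O)cc1`, has not yet been measured in this assay. It is derived from compound 2 by acetyl in place of phenylsulfamoyl on an aromatic carbon. For the measured compounds named here, the acetyl is a far smaller group than the phenylsulfamoyl it replaces, and the only other measured compound, compound 1, gives a number rather than a limit with 1450 nM. On that basis the step of an at least 3.5-fold lower number from compound 2 to compound 3 (0.55 log units; beyond the scatter) is expected to run toward smaller concentrations, beyond the usual scatter, although a reading that again ends at a limit cannot be ruled out. Compound 3 is therefore estimated at 3500 nM, with a plausible range from 900 nM to 12500 nM.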

Compound 3, half-maximal effective concentration: > 12500 nM
Compound 3: no number, only a limit; the forecaster's own chance of this, stated with the estimate: 30%; middle value at least 3.5-fold (0.55 log units) from the limit.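

In this assay compound 3 gives > 12500 nM, which is a limit and not a number. Among the compounds shown here, compound 2 also ends at a limit, so no step from compound 2 to compound 3 can be read: the limit of > 12500 nM in this assay, at which 2 of the 3 values shown sit. The compounds shown leave open where compound 2 and compound 3 truly lie on the scale, and whether acetyl in place of phenylsulfamoyl shifts the read-out at all.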